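Swapping an Oxetane for a Cyclopropyl on the Piperazine

A few compounds are considered here, and "the series" means these few. Any claim that something is new, unique, unknown or untested is made for them only; others in the source may bear on it.

Three compounds have been measured in a functional assay on CCRF-CEM cells for antagonist activity at C-X-C chemokine receptor type 4 (Homo sapiens), read by calcium flux, with stated times of 25 min and 90 s; a lower number here means a stronger inhibitor, a higher number a weaker inhibitor:

compound 1 `c1cnc2c(c1)CCC[C@@H]2N(CC1CC1)C[C@H]1Cc2c(cccc2N2CCNCC2)CN1`: 26.7 nM
compound 2 `CN(C[C@H]1Cc2c(cccc2N2CCN(C3COC3)CC2)CN1)[C@H]1CCCc2cccnc21`: 381 nM
compound 3 `Cc1cnc(CN(C)C[C@H]2Cc3c(cccc3N3CCNCC3)CN2)c(C)c1`: 21.4 nM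

Compound 2 gives the highest number of the three. Compound 1 and compound 3, each carrying a piperazine ring with nothing on its second nitrogen, give lower numbers, and the gap from compound 2 to either of them lies beyond the scatter of this assay.

Compound 4 `CN(C[C@H]1Cc2c(cccc2N2CCN(C3CC3)CC2)CN1)[C@H]1CCCc2cccnc21` has not yet been measured. It differs from compound 2 in one place: cyclopropyl in place of oxetan-3-yl on an amine nitrogen in a ring. Going by the values given here, no measured pair shows this exact change, so its size can only be guessed. Compound 4 still carries a small ring on that nitrogen, as compound 2 does, rather than the free nitrogen of compound 1 and compound 3, so the step from compound 2 to compound 4 is expected to be modest, at most a mild move toward a lower number, and may fall within the scatter: a 1.5-fold lower number from compound 2 to compound 4 (0.18 log units; within the scatter). Compound 4 is therefore estimated at 250 nM, with a plausible range from 80 nM to 800 nM.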

Compound 4, half-maximal inhibitory concentration: 23.5 nM
Compound 4: middle estimate off by 11-fold (1.03 log units), on the high side; the whole stated range lies above it.
By their numbers in this assay, from the lowest: compounds 3, 4 and 1 (each within the scatter of the next); then compound 2.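

In this assay, cyclopropyl in place of oxetan-3-yl on the amine nitrogen of the piperazine gives a 16-fold lower number from compound 2 to compound 4 (1.21 log units; beyond the scatter), so this position responds strongly to which small ring it carries. A ring on this nitrogen therefore does not by itself bring a high number, as compound 4 carries one and gives 23.5 nM. Nothing at hand explains why these two rings differ so sharply.

The compounds shown leave open whether the oxygen or the ring size accounts for the step: a cyclobutyl group, a four-membered ring of carbon only, would separate the two. They also leave open how an open chain such as isopropyl, in place of a ring, would fare on this nitrogen.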